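Homologation at a chain carbon in two core series

The compounds below may be only part of what the source reports. "The series", "measured", "known", "first", "only" and "open" are said of these compounds alone.

Compound 1 `CC(C)(C)c1ccc2nc(N)sc2c1` gives 4 mg/kg in a functional assay on the whole organism with Rattus norvegicus as the target; a higher number here means that more compound is needed for the effect, a lower number that less compound is needed. Compound 2 `CCC(C)(C)c1ccc2nc(N)sc2c1` reaches only a limit of this assay, > 10 mg/kg. The change between them, (methyl in place of hydrogen on a saturated chain carbon, two bonds along the chain from an aromatic carbon), therefore made an at least 2.5-fold higher number from compound 1 to compound 2 (0.39 log units; beyond the scatter), an outcome that rests on (the limit of > 10 mg/kg in this assay, at which 1 of the 3 values shown sits). Compound 3 `CSCCn1c(=N)sc2cc(OC(F)(F)F)ccc21` gives 1 mg/kg in this assay, the lowest number of the two that were measured, and the difference between its core and that of compound 1 is not broken down here. Compound 4 `CCSCCn1c(=N)sc2cc(OC(F)(F)F)ccc21` is not yet measured; it differs from compound 3 by methyl in place of hydrogen on a saturated chain carbon bound to a sulfur, the same kind of change as from compound 1 to compound 2, though the place is not the same: there the carbon was two bonds along the chain from an aromatic carbon, here it is bound to a sulfur. Since the earlier step made the number rise, a smaller rise is expected for compound 4 as well, a 2.0-fold higher number from compound 3 to compound 4 (0.30 log units; within the scatter), leading to an expected value of 2 mg/kg, between 0.7 mg/kg and 6 mg/kg.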

Compound 4, dose for half-maximal effect: 2.2 mg/kg
Beside the measured number, compound 4's estimate is 1.1-fold (0.04 log units) below it, within the range that was stated.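

In this assay, turning the methylsulfanyl group of compound 3 into the ethylsulfanyl group of compound 4 gave a 2.2-fold higher number from compound 3 to compound 4 (0.34 log units; beyond the scatter), so the same change moved the number in the same direction on both cores: the same change on two cores in this assay, an at least 2.5-fold higher number (0.39 log units; beyond the scatter) from compound 1 to compound 2 and a 2.2-fold higher number (0.34 log units; beyond the scatter) from compound 3 to compound 4; the limit leaves it open whether they differ. From the compounds shown here alone, compound 2 gives only a limit of the assay, > 10 mg/kg, and not a number, so the full size of the earlier step stays unknown: the limit of > 10 mg/kg in this assay, at which 1 of the 4 values shown sits. The shared direction rests on these two pairs alone, and it does not separate the effect of the core from that of the place, since the changed carbon lies two bonds along the chain from an aromatic carbon in one pair and is bound to a sulfur in the other.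

The compounds shown leave open whether a longer chain on the sulfur, such as propyl or butyl, would raise the number further. They also leave open how an ether oxygen in place of the sulfur, or an amine or a carboxylic acid at the chain end, would read in this assay.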